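The compounds below may be only part of what the source reports. "The series", "measured", "known", "first", "only" and "open" are said of these compounds alone.

In a functional assay on DU-145 cells (Homo sapiens) for inhibition, read by trypan blue exclusion, with a stated time of 96 h (a higher number here means a weaker inhibitor of growth, a lower number a stronger inhibitor of growth), compound 1 `COc1ccccc1/C=C(/SCc1ccc(Cl)cc1)C(=O)c1ccc([N+](=O)[O-])cc1` gives 10000 nM and compound 2 `Cc1ccc(/C=C(/SCc2ccc(Cl)cc2)C(=O)c2ccc(Cl)cc2)s1` gives 50000 nM, the higher of the two numbers and beyond the scatter from compound 1. Compound 3 `Cc1ccc(/C=C(/SCc2ccc(Cl)cc2)C(=O)c2ccc([N+](=O)[O-])cc2)s1` differs from compound 2 in one place: nitro in place of chloro on an aromatic carbon. Among the compounds with values here, no measured pair isolates this change. However, compound 1, which also carries a 4-nitrophenyl, stands at 10000 nM, so a moderate move to a lower number, beyond the scatter, is expected. The expected change is a 3.3-fold lower number from compound 2 to compound 3 (0.52 log units; beyond the scatter). For compound 3 the estimated value is 15000 nM, within a range of 5000 nM to 50000 nM.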

Compound 3, concentration for 50% growth inhibition: 25000 nM
Beside the measured number, compound 3's estimate is 1.7-fold (0.22 log units) below it; the range from low to high includes it.
By their numbers in this assay, from the lowest: compound 1; then compounds 3 and 2 (each within the scatter of the next).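

In this assay, nitro in place of chloro on an aromatic carbon, para to a large group, gives a 2.0-fold lower number from compound 2 to compound 3 (0.30 log units; within the scatter), so this change does not separate the two compounds on the 5-methylthiophen-2-yl background. With the 4-nitrophenyl held constant, 5-methylthiophen-2-yl in place of 2-methoxyphenyl gives a 2.5-fold higher number from compound 1 to compound 3 (0.40 log units; beyond the scatter), a step that, unlike the first, lies beyond the scatter. Nothing available explains either step. Still open, as far as these compounds go, is how an amine or a carboxylic acid at this ring position would read, and whether the 4-chlorophenyl and 4-nitrophenyl would also stay within the scatter of each other alongside the 2-methoxyphenyl.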